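Calpain-1 Inhibition: Chloro in Place of Bromo

A few compounds are considered here, and "the series" means these few. Any claim that something is new, unique, unknown or untested is made for them only; others in the source may bear on it.

Measured compounds:
compound 1 `O=C(O)/C(S)=C/c1c[nH]c2c(F)cccc12` – 120 nM
compound 2 `O=C(O)/C(S)=C/c1c[nH]c2c(Br)cccc12` – 2 nM

Compound 2 gives the lowest number of the two in an assay on isolated protein for inhibition of Calpain-1 catalytic subunit (Sus scrofa), read by FRET; on this read-out higher numbers stand for weaker inhibition and lower numbers for stronger inhibition; its nearest neighbour is compound 1, and the step of a 60-fold lower number from compound 1 to compound 2 (1.78 log units; beyond the scatter) lies beyond the scatter. Compound 3 `O=C(O)/C(S)=C/c1c[nH]c2c(Cl)cccc12` differs from compound 2 by chloro in place of bromo on an aromatic carbon. Going by the values given here, the only step that bears on this change is the one from compound 1 to compound 2, which was large. For compound 3 a step of a 5.0-fold higher number from compound 2 to compound 3 (0.70 log units; beyond the scatter) toward a higher number is therefore expected, though a smaller one than that step. Compound 3 is estimated at 10 nM, within 2 nM to 50 nM.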

Compound 3, half-maximal inhibitory concentration: 10 nM
Compound 3: the middle estimate sits on the measured number at the digits printed; measured number inside the range.
By their numbers in this assay, from the lowest: compound 2; then compound 3; then compound 1.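

With chloro on this aromatic carbon, the halogen series gains a middle point in this assay, with a 5.0-fold higher number from compound 2 to compound 3 (0.70 log units; beyond the scatter) and a 12-fold lower number from compound 1 to compound 3 (1.08 log units; beyond the scatter). The earlier pair showed only that bromo and fluoro differ; the three halogens now give numbers that lie beyond the scatter of one another, running bromo, chloro, fluoro from the lowest. Nothing available explains this order. Going by these compounds, it remains open whether iodo on the same carbon would extend the order, and whether an amine there would keep a low number.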